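The source may report more compounds than this note shows. Statements on the series, on what has been measured and on what is new or still open speak of the compounds shown alone.

Compound 3 `O=C(/C=C/c1cccc(NS(=O)(=O)c2ccccc2Cl)c1)c1nc2ccccc2[nH]1` gives 4790 nM in a functional assay on 143B cells (Homo sapiens) for antiproliferative activity, read by MTT assay, with a stated time of 48 h (on this read-out lower numbers stand for stronger inhibition and higher numbers for weaker inhibition), the lowest number of the three, though every gap to it stays within the scatter: compound 2 `O=C(/C=C/c1cccc(NC(=O)c2ccccc2Br)c1)c1nc2ccccc2[nH]1` gives 6050 nM and compound 1 `O=C(Nc1cccc(/C=C/C(=O)c2nc3ccccc3[nH]2)c1)c1ccc(Cl)cc1` gives 7440 nM, with a 1.6-fold lower number from compound 1 to compound 3 (0.19 log units; within the scatter) and a 1.3-fold lower number from compound 2 to compound 3 (0.10 log units; within the scatter). Compound 4 `Cc1cccc(S(=O)(=O)Nc2cccc(/C=C/C(=O)c3nc4ccccc4[nH]3)c2)c1` differs from compound 3 by 3-methylphenyl in place of 2-chlorophenyl on a sulfonyl sulfur. The one aryl-for-aryl exchange measured so far, a 1.2-fold lower number from compound 1 to compound 2 (0.09 log units; within the scatter) on a carbonyl carbon, stayed within the scatter, and the amide-to-sulfonamide steps did too; the series has shown no step beyond the scatter. For this exchange on the sulfonyl sulfur no step beyond the scatter in this assay is expected either. Compound 4 is estimated at 5000 nM, range 2400 nM to 10500 nM. The expected step is a 1.0-fold higher number from compound 3 to compound 4 (0.02 log units; within the scatter), within the scatter.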

Compound 4, half-maximal inhibitory concentration: 791 nM
Beside the measured number, compound 4's estimate is 6.3-fold (0.80 log units) above it; measured number below the stated range.
By their numbers in this assay, from the lowest: compound 4; then compounds 3, 2 and 1 (each within the scatter of the next).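

In this assay, within the data shown here, the sulfonyl sulfur is the first place where an aryl exchange goes beyond the scatter, with a 6.1-fold lower number from compound 3 to compound 4 (0.78 log units; beyond the scatter) on this change. The (3-methylphenyl)sulfonyl group also clears the scatter against the carbonyl-linked aryl groups, with a 7.6-fold lower number from compound 2 to compound 4 (0.88 log units; beyond the scatter) and a 9.4-fold lower number from compound 1 to compound 4 (0.97 log units; beyond the scatter) here, while the 2-chlorophenyl sulfonyl of compound 3 did not, so the sulfonyl link alone does not carry the step. No measurement shown accounts for this step.

Going by these compounds, whether the step follows the methyl itself or the different ring position stays open, and a 3-chlorophenyl or 2-methylphenyl on the sulfonyl sulfur would separate the two. On these data alone, how an amine or a longer chain in place of the methyl would read is also open.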